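Replacing the 2,5-dimethoxyphenyl group of compound 1

The compounds below may be only part of what the source reports. "The series", "measured", "known", "first", "only" and "open" are said of these compounds alone.

Values measured in an ADME assay on L132 cells (Homo sapiens) for cytotoxicity, read by MTT assay, with a stated time of 72 h (on this read-out lower numbers stand for stronger inhibition and higher numbers for weaker inhibition), are as follows.
- Compound 1 `COc1ccc(OC)c(C2=C(c3cc(OC)c(OC)c(OC)c3)C(=O)CC2O[SiH2]C(C)(C)C)c1` gives 100 ug/mL as a number.
- Compound 2 `COc1ccc(OC)c(C2=C(c3cc(OC)c(OC)c(OC)c3)C(=O)CC2O)c1` gives > 100 ug/mL as a limit.

For the measured compounds named here, compound 1 holds the only number in this small set, and the one other value is a limit. Compound 3 `COCOc1cc(C2=C(c3cc(OC)c(OC)c(OC)c3)C(=O)CC2O[SiH2]C(C)(C)C)ccc1OC` keeps the rest of compound 1 and changes one group on a double-bonded ring carbon: 4-methoxy-3-(methoxymethoxy)phenyl in place of 2,5-dimethoxyphenyl on a double-bonded ring carbon (4-methoxy-3-(methoxymethoxy)phenyl in place of 2,5-dimethoxyphenyl).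

Going by the values given here, the single measured step, a number no lower from compound 1 to compound 2 (the limit leaves the size open), lies elsewhere, on an oxygen on a saturated carbon. Going by these compounds, its size stays open because of the limit of > 100 ug/mL in this assay, at which 1 of the 2 values shown sits, and it says nothing about the new group. Among the compounds with values here, no measured step touches this group, so the data give no size for the change. Within the data shown here, the only numerical anchor is compound 1 at 100 ug/mL, and compound 3 keeps the group on the oxygen that compound 1 carries. With no direction to go on, the step of a 1.3-fold lower number from compound 1 to compound 3 (0.10 log units; within the scatter) is expected to stay within the scatter. In this assay compound 3 is estimated at 80 ug/mL, with the expected range running from 25 ug/mL to 200 ug/mL on that read-out.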

Compound 3, half-maximal inhibitory concentration: 32 ug/mL
The estimate for compound 3 lay 2.5-fold (0.40 log units) above the measured number, and the stated range covers the measured number.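

In this assay, for the compounds shown here, the change to 4-methoxy-3-(methoxymethoxy)phenyl gives the first step in this set with a readable size: a 3.1-fold lower number from compound 1 to compound 3 (0.49 log units; beyond the scatter). Going by these compounds alone, this shows that the group on a double-bonded ring carbon of the five-membered ring affects the read-out, which the earlier compounds could not show, as they differ only on the oxygen on a saturated carbon. The step rests on a single pair of compounds, and nothing measured here accounts for it.

Compound 2 holds a limit, so its step from compound 1 cannot be read in size, and the effect of the group on the oxygen cannot be set against that of the aryl change: the limit of > 100 ug/mL in this assay, at which 1 of the 3 values shown sits. The swap also replaces 2,5-dimethoxyphenyl as a whole, so the compounds shown leave open which part of 4-methoxy-3-(methoxymethoxy)phenyl carries the step, and whether a free hydroxyl, an amine or a carboxylic acid in place of the methoxymethoxy group would move the number further in this assay.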